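The compounds below may be only part of what the source reports. "The series", "measured", "known", "first", "only" and "open" are said of these compounds alone.

Compound 3 `CC(=O)O[C@@H]1OC(=O)[C@@](C)(C(C)=O)[C@@H]1C` gives 9000 nM in a functional assay on DA-3 cells for cytotoxicity against DA-3 cell line (Mus musculus), read by MTT assay (on this read-out higher numbers stand for weaker inhibition and lower numbers for stronger inhibition), and stands as the higher of the two numbers reported, though its gap to compound 1 `CC(=O)O[C@@H]1OC(=O)[C@](C)(C(C)=O)[C@@H]1C`, which gives 7000 nM, is a 1.3-fold higher number from compound 1 to compound 3 (0.11 log units; within the scatter) and so lies within the scatter; the two differ only in the configuration as drawn (the fact that compounds 1 and 3 differ only in the configuration as drawn). Compound 2 `CC(=O)O[C@@H]1OC(=O)[C@](O)(C(C)=O)[C@@H]1C` reaches only the limit of this assay, > 50000 nM.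

The step to compound 4 `CC(=O)O[C@@H]1OC(=O)[C@@](O)(C(C)=O)[C@@H]1C` is hydroxy in place of methyl on a saturated ring carbon. Among the compounds with values here, the one measured step that bears on it is an at least 7.1-fold higher number from compound 1 to compound 2 (0.85 log units; beyond the scatter), a step that runs from a number to the limit (the limit of > 50000 nM in this assay, at which 1 of the 3 values shown sits), so its full size is not known. Applied to compound 3 the same change is expected to give a 7.8-fold higher number from compound 3 to compound 4 (0.89 log units; beyond the scatter) in this assay, towards a higher number. Compound 4 is expected at about 70000 nM, with a range of 30000 nM to 200000 nM, and is likely to be reported only as a limit in this assay.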

Compound 4, half-maximal inhibitory concentration: > 50000 nM
Compound 4: only a limit was reported (the forecaster's own chance of this, stated with the estimate: 70%); the middle value lies beyond the limit too.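

With compound 4, the change from methyl to hydroxy on this saturated ring carbon has now been read on both drawn configurations at that carbon, and in this assay the second reading is an at least 5.5-fold higher number from compound 3 to compound 4 (0.74 log units; beyond the scatter). The shift to a higher number is therefore not confined to one configuration, and it holds on both pairs: the same change on two cores in this assay, an at least 7.1-fold higher number (0.85 log units; beyond the scatter) from compound 1 to compound 2 and an at least 5.5-fold higher number (0.74 log units; beyond the scatter) from compound 3 to compound 4; the limit leaves it open whether they differ In this series, compound 4 gives > 50000 nM, which is a limit of the assay and not a number.

Going by these compounds, the step between compound 2 and compound 4 cannot be read, so any effect of configuration among the hydroxy compounds stays open: the limit of > 50000 nM in this assay, at which 2 of the 4 values shown sit. Also open is whether another group on this ring carbon, such as methoxy, an amine or a longer chain, would give a number in this assay rather than a limit.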